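Aryl to benzyl swap on the amine nitrogen: notes

The compounds below may be only part of what the source reports. "The series", "measured", "known", "first", "only" and "open" are said of these compounds alone.

Compound 1 `Cc1ccc(S(=O)(=O)/N=C(/CCNC2=CC(=O)c3ccccc3C2=O)Nc2cccc(C(F)(F)F)c2)cc1`: 77600 nM
Compound 2 `Cc1ccc(S(=O)(=O)/N=C(/CCNC2=CC(=O)c3ccccc3C2=O)Nc2ccc(F)c(F)c2)cc1`: 8790 nM
Compound 3 `COc1ccc(N/C(CCNC2=CC(=O)c3ccccc3C2=O)=N\S(=O)(=O)c2ccc(C)cc2)c(OC)c1`: 67600 nM

All three share one core and differ only in the group on the amine nitrogen. In a functional assay on HeLa cells (Homo sapiens) for cytotoxicity, read by MTT assay, with a stated time of 48 h (a higher number here means a weaker inhibitor, a lower number a stronger inhibitor), compound 3 stands second highest of the three: near compound 1, with a 1.1-fold lower number from compound 1 to compound 3 (0.06 log units; within the scatter), and far from compound 2, with a 7.7-fold higher number from compound 2 to compound 3 (0.89 log units; beyond the scatter). Compound 4 `Cc1ccc(S(=O)(=O)/N=C(/CCNC2=CC(=O)c3ccccc3C2=O)NCc2ccccc2)cc1` changes that position again: benzyl in place of 2,4-dimethoxyphenyl on an amine nitrogen. Among the compounds with values here, no measured step covers a benzyl group, so the two aryl steps an 8.8-fold lower number from compound 1 to compound 2 (0.95 log units; beyond the scatter) and a 7.7-fold higher number from compound 2 to compound 3 (0.89 log units; beyond the scatter) set only the scale of what this position can move. Compound 4 is expected near compound 3, estimated at 50000 nM (range 12000 nM to 200000 nM), a change of a 1.4-fold lower number from compound 3 to compound 4 (0.13 log units; within the scatter), direction uncertain.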

Compound 4, half-maximal inhibitory concentration: 3980 nM
Estimate against measurement, compound 4: 13-fold (1.10 log units) above; measured number below the stated range.
By their numbers in this assay, from the lowest: compound 4; then compound 2; then compounds 3 and 1 (each within the scatter of the next).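

In this assay benzyl gives the lowest number at this position, with a 17-fold lower number from compound 3 to compound 4 (1.23 log units; beyond the scatter) and a 19-fold lower number from compound 1 to compound 4 (1.29 log units; beyond the scatter) and a 2.2-fold lower number from compound 2 to compound 4 (0.34 log units; beyond the scatter) as its steps. The position therefore tolerates a group other than a substituted aryl, and the range of numbers reached here extends beyond what the aryl compounds alone showed. The smallest of these steps starts from the 3,4-difluorophenyl compound, so this aryl group stands closest to benzyl among the groups shown.

Going by these compounds, whether the gain follows from benzyl itself or from the absence of ring substituents remains open, and an unsubstituted phenyl, a 4-methoxybenzyl or a longer phenethyl chain would separate the two. Nothing measured here accounts for the result.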